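The source may hold more compounds than are shown below. What is called first, only, known or untested is meant among the compounds shown, and "the series" means these compounds.

Among the compounds with values here, in a functional assay on L1210 cells (Mus musculus), read by cell counting, with a stated time of 48 h (on this read-out higher numbers stand for weaker inhibition and lower numbers for stronger inhibition), two compounds have numbers so far. Compound 1 `COc1ccc(/C=C/c2ccc(F)cc2)cc1` gives 26 ug/mL in this assay. Compound 2 `Cc1ccc(/C=C/c2ccc(N(C)C)cc2)cc1` gives 143 ug/mL in this assay, the highest of the two numbers shown, and its nearest neighbour is compound 1 with a lower number, a gap beyond the scatter.

Compound 3 `COc1ccc(/C=C/c2ccc(C)cc2)cc1` has not yet been measured in this assay. It is reached from compound 2 by the change (methoxy in place of dimethylamino on an aromatic carbon), that is, methoxy in place of dimethylamino on an aromatic carbon, para to a group of 9 heavy atoms. Within the data shown here, no measured pair in this set shows this exact change, so the expected size of the step rests only on the two numbers available. Compound 1 carries the methoxy group and gives the lower number of the pair, while compound 2 carries the dimethylamino group and gives the higher one, so the step from compound 2 to compound 3 is expected to lower the number, by an amount a 2.9-fold lower number from compound 2 to compound 3 (0.46 log units; beyond the scatter) that may reach beyond the scatter. Compound 3 is therefore estimated to give 50 ug/mL in this assay, within a range from 15 ug/mL to 150 ug/mL.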

Compound 3, half-maximal inhibitory concentration: > 200 ug/mL
Compound 3 was reported as a limit (the forecaster's own chance of this, stated with the estimate: 5%); middle value at least 4.0-fold (0.60 log units) away from the limit.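

Compound 3 is reported only as a limit, not as a number: the limit of > 200 ug/mL in this assay, at which 1 of the 3 values shown sits. In this assay, within the data shown here, methyl in place of fluoro on an aromatic carbon, with the methoxy group kept, gives an at least 7.6-fold higher number from compound 1 to compound 3 (0.88 log units; beyond the scatter), the first change in one place in this set and one that shows the group at this place can move the read-out beyond the scatter. Methoxy in place of dimethylamino on an aromatic carbon gives an at least 1.3-fold higher number from compound 2 to compound 3 (0.14 log units; that floor lies within the scatter), so this change is bounded from one side only and its full size cannot be read, yet compound 3 shows that methoxy alone does not bring the low number of compound 1.

Among the compounds shown, only fluoro and methyl can be compared with the methoxy group held constant, so it stays open where a chloro group, a hydroxyl group or a carboxylic acid would fall at that place. On these data alone, it also stays open whether fluoro in place of methyl would lower the number to a similar extent in a compound carrying dimethylamino instead of methoxy.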